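Ethylpiperazine for Dimethylpiperazine on a Fused Aromatic Core

The source may report more compounds than this note shows. Statements on the series, on what has been measured and on what is new or still open speak of the compounds shown alone.

Compound 1: `C[C@@H]1CN(c2cccc3c2C[C@H](CN(C)[C@H]2CCCc4cccnc42)NC3)C[C@H](C)N1` — 61 nM
Compound 2: `Cc1cnc2c(c1)CCC[C@@H]2N(C)C[C@H]1Cc2c(cccc2N2CCNCC2)CN1` — 16.1 nM

Of the compounds shown here, two have been measured in a functional assay on CCRF-CEM cells for antagonist activity at C-X-C chemokine receptor type 4 (Homo sapiens), read by calcium flux, with stated times of 25 min and 90 s; on this read-out higher numbers stand for weaker inhibition and lower numbers for stronger inhibition. Compound 1 gives 61 nM, the higher of the two numbers; compound 2 gives 16.1 nM, a gap that lies beyond the usual scatter. No single-point change links these two, so nothing more than that comparison is drawn from them.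

Compound 3 is `CCN1CCN(c2cccc3c2C[C@H](CN(C)[C@H]2CCCc4cccnc42)NC3)CC1`. It differs from compound 1 in the group on the aromatic carbon: 4-ethylpiperazin-1-yl in place of 3,5-dimethylpiperazin-1-yl on an aromatic carbon. The hydrogen-bond donor of the ring is lost, the atom count is unchanged, and the two stereocentres of the leaving group do not reappear.

Among the measured compounds shown here, no measured step of this kind exists here, so the expectation rests on compound 1 alone. Compound 3 is expected to give 50 nM, with a range of 15 nM to 180 nM. The step of a 1.2-fold lower number from compound 1 to compound 3 (0.09 log units; within the scatter) is estimated to stay within the scatter, in either direction.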

Compound 3, half-maximal inhibitory concentration: 13.8 nM
Compound 3: middle estimate off by 3.6-fold (0.56 log units), on the high side; the measured number lies below the stated range.
By their numbers in this assay, from the lowest: compounds 3 and 2 (each within the scatter of the next); then compound 1.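

In this assay, among the compounds shown here, this position on the aromatic carbon responds to an exchange of one piperazine for another of equal size: 4-ethylpiperazin-1-yl in place of 3,5-dimethylpiperazin-1-yl gives a 4.4-fold lower number from compound 1 to compound 3 (0.65 log units; beyond the scatter) and is the first single-place change to show such an effect. The ring's hydrogen-bond donor and its two defined stereocentres are therefore not required for a number of this size on this core. No evidence on hand accounts for the step.

This single step moves the donor, the two methyl groups and the ethyl group together, so their separate contributions remain unresolved. Also open, as far as these compounds go, is how 4-methylpiperazin-1-yl, or a morpholine ring with oxygen in place of the distal nitrogen, would read at this position on the core of compound 3 .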